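This account rests on a few compounds, and the source may have more. Where it says the series, first, only, none or still open, it means among the compounds named here.

Compound 1 `CC(C)CCn1cnc2c(Nc3ccc(Cl)cc3)nc(N[C@H]3CC[C@H](N)CC3)nc21`: 2700 nM
Compound 2 `CCCCCCn1cnc2c(Nc3ccc(Cl)cc3)nc(N[C@H]3CC[C@H](N)CC3)nc21`: 4200 nM
Compound 3 `CCCCn1cnc2c(Nc3ccc(Cl)cc3)nc(N[C@H]3CC[C@H](N)CC3)nc21`: 2100 nM

These values come from a functional assay on MCF7 cells (Homo sapiens) for inhibition, read by fluorescence, with a stated time of 72 h; on this read-out lower numbers stand for stronger inhibition of growth and higher numbers for weaker inhibition of growth. Compound 1 stands close to both of the others, with a 1.3-fold lower number from compound 1 to compound 3 (0.11 log units; within the scatter) and a 1.6-fold higher number from compound 1 to compound 2 (0.19 log units; within the scatter).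

Compound 4 `CC(C)CCn1cnc2c(Nc3ccccc3)nc(N[C@H]3CC[C@H](N)CC3)nc21` keeps the chain of compound 1 and differs in one place: hydrogen in place of chloro on an aromatic carbon. Among the measured compounds shown here, none of the measured steps touches the chloro. All three alter the chain, and even a 2.0-fold lower number from compound 2 to compound 3 (0.30 log units; within the scatter) does not leave the scatter. The data therefore give no direction for this change, and no step beyond the scatter is expected. The expected outcome is a 1.1-fold higher number from compound 1 to compound 4 (0.05 log units; within the scatter). The estimate stays near compound 1 at 2700 nM. Compound 4 is estimated at 3000 nM, with an expected range from 1200 nM to 8000 nM.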

Compound 4, concentration for 50% growth inhibition: 5400 nM
Compound 4: middle estimate off by 1.8-fold (0.26 log units), on the low side; the measured number falls inside the stated range.
By their numbers in this assay, from the lowest: compounds 3, 1, 2 and 4 (each within the scatter of the next, the first and the last beyond it).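

Among the compounds shown here, compound 4 is the first compound here altered on the aromatic ring rather than the chain, and hydrogen in place of chloro gives a 2.0-fold higher number from compound 1 to compound 4 (0.30 log units; within the scatter). This one pair therefore gives no firm sign that the chloro matters for growth inhibition in these cells. No measured evidence bears on this result. Still open, as far as these compounds go, is whether another group at this position, such as fluoro, methoxy or nitrile, would move the number beyond the scatter. Also open, from the compounds shown here alone, is whether removing chloro behaves alike with the butyl chain of compound 3.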